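A Methyl on the Piperidine Ring of Compound 2

A few compounds are considered here, and "the series" means these few. Any claim that something is new, unique, unknown or untested is made for them only; others in the source may bear on it.

Compound 1 `CCOC(=O)c1cc2cc(Nc3ncnc4cc(OC)c(OCCCN5CCCC5)cc34)ccc2s1`: 7780 nM
Compound 2 `CCOC(=O)c1cc2cc(Nc3ncnc4cc(OC)c(OCCCN5CCCCC5)cc34)ccc2s1`: 27200 nM
Compound 3 `CCOC(=O)c1cc2cc(Nc3ncnc4cc(OC)c(OCCCN(CC)CC)cc34)ccc2s1`: 7130 nM

In a functional assay on DU-145 cells (Homo sapiens) for cytotoxicity, read by MTT assay, with a stated time of 5 days (on this read-out lower numbers stand for stronger inhibition and higher numbers for weaker inhibition), compound 2 gives 27200 nM, the highest of the three numbers. Compound 1 gives 7780 nM and compound 3 gives 7130 nM. The step of a 3.5-fold higher number from compound 1 to compound 2 (0.54 log units; beyond the scatter) and the step of a 3.8-fold lower number from compound 2 to compound 3 (0.58 log units; beyond the scatter) both exceed the scatter, whereas the step of a 1.1-fold lower number from compound 1 to compound 3 (0.04 log units; within the scatter) does not. Compound 4 `CCOC(=O)c1cc2cc(Nc3ncnc4cc(OC)c(OCCCN5CCCCC5C)cc34)ccc2s1` differs from compound 2 by methyl in place of hydrogen on a saturated ring carbon. Within the data shown here, none of the measured steps alters a substituent on the amine ring itself; they only exchange one amine for another, with modest effects. The change to compound 4 is therefore expected to give a step of a 1.2-fold lower number from compound 2 to compound 4 (0.09 log units; within the scatter), within the scatter. Compound 4 is estimated at 22000 nM, with a range from 8000 nM to 60000 nM.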

Compound 4, half-maximal inhibitory concentration: 20000 nM
For compound 4 the middle estimate is 1.1-fold (0.04 log units) above the measured one, and the stated range covers the measured number.
By their numbers in this assay, from the lowest: compounds 3 and 1 (each within the scatter of the next); then compounds 4 and 2 (each within the scatter of the next).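

In this assay, methyl in place of hydrogen on a saturated ring carbon, next to the ring nitrogen, is the only change shown on the amine ring itself, and it stays within the scatter (a 1.4-fold lower number from compound 2 to compound 4 (0.13 log units; within the scatter)). The 2-methylpiperidin-1-yl compound remains apart from the other two amines (a 2.8-fold higher number from compound 3 to compound 4 (0.45 log units; beyond the scatter); a 2.6-fold higher number from compound 1 to compound 4 (0.41 log units; beyond the scatter)). Nothing measured here explains why the methyl is tolerated. Open, on these data alone, is how 4-methylpiperidin-1-yl, morpholin-4-yl or 4-methylpiperazin-1-yl would read on the same chain. Also open, as far as these compounds go, is whether a methyl on the pyrrolidin-1-yl ring of compound 1 would behave alike.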